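Phenylpropyl Amide in Place of the Ethyl Ester

A few compounds are considered here, and "the series" means these few. Any claim that something is new, unique, unknown or untested is made for them only; others in the source may bear on it.

Among the measured compounds shown here, compound 3 `CCCSc1nc(Cl)c2c(n1)N(Cc1ccccc1)C(C(=O)OCC)N2` is the one member of this set with a number in a functional assay on PC-3 cells (Homo sapiens) for antiproliferative activity, read by MTT assay, with a stated time of 72 h; a lower number here means a stronger inhibitor, a higher number a weaker inhibitor; in this assay compound 3 gives 62500 nM. Compound 1 `CCCSc1nc(Cl)c2c(n1)N(Cc1ccccc1)C(C(=O)NCCC1=CCc3ccccc31)N2` reaches only a limit in this assay, where compound 1 gives > 64000 nM. Compound 2 `CCCSc1nc(Cl)c2c(n1)N(Cc1ccccc1)C(C(=O)NCC(C)C)N2` likewise reaches only a limit, giving > 64000 nM. The step that the two limits leave unreadable from compound 1 to compound 2 therefore cannot be sized, and the step of an at least 1.0-fold lower number from compound 2 to compound 3 (0.01 log units; that floor lies within the scatter) shows no change beyond the scatter; the shared picture is the limit of > 64000 nM in this assay, at which 2 of the 3 values shown sit.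

Compound 4 `CCCSc1nc(Cl)c2c(n1)N(Cc1ccccc1)C(C(=O)NCCCc1ccccc1)N2` differs from compound 3 by (3-phenylpropyl)amino in place of ethoxy on a carbonyl carbon. The reverse of the step from compound 2 to compound 3, an alkylamino replacing an ethoxy on the carbonyl carbon, stayed within the scatter, and compound 1, carrying a larger arylalkyl group on the amide nitrogen, sits at the limit. The expected step of a 1.0-fold higher number from compound 3 to compound 4 (0.01 log units; within the scatter) is thus small, with the number likely ending at or beyond the limit. Compound 4 is estimated at 64000 nM, between 30000 nM and 150000 nM.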

Compound 4, half-maximal inhibitory concentration: 12700 nM
The estimate for compound 4 lay 5.0-fold (0.70 log units) above the measured number, and the stated range ends above it.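

In this assay, among the compounds shown here, (3-phenylpropyl)amino on the carbonyl carbon gives a 4.9-fold lower number from compound 3 to compound 4 (0.69 log units; beyond the scatter), the first step at this place that reads beyond the scatter. The group on the amide nitrogen also matters: phenethyl in place of isopropyl on the saturated chain carbon gives an at least 5.0-fold lower number from compound 2 to compound 4 (0.70 log units; beyond the scatter), and the group with only a six-membered aromatic ring in place of the one that also holds a five-membered non-aromatic ring gives an at least 5.0-fold lower number from compound 1 to compound 4 (0.70 log units; beyond the scatter). Both of these steps are floors, since the amides they start from stand at a limit: the limit of > 64000 nM in this assay, at which 2 of the 4 values shown sit.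

As far as these compounds go, whether a shorter 2-phenylethyl or a longer 4-phenylbutyl group on the amide nitrogen would keep this gain remains open. So does the effect of a pyridine ring in place of the phenyl, or of a methoxy group on it.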